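This account rests on a few compounds, and the source may have more. Where it says the series, first, only, none or still open, it means among the compounds named here.

Measured so far:
Compound 1 `NS(=O)(=O)c1ccc(/C=C/c2ccc(F)cc2)cc1`: 7970 nM
Compound 2 `NS(=O)(=O)c1ccc(/C=C/c2cccc(O)c2)cc1`: 25800 nM

In a functional assay on NCI-H226 cells (Homo sapiens) for inhibition (on this read-out lower numbers stand for stronger inhibition of growth and higher numbers for weaker inhibition of growth), compound 1 gives 7970 nM, the lower of the two numbers, and compound 2 gives 25800 nM, a gap beyond the usual scatter. Compound 3 `CN(C)c1ccc(/C=C/c2ccc(S(N)(=O)=O)cc2)cc1` keeps the core of compound 1, with dimethylamino in place of fluoro on an aromatic carbon, para to a large group: dimethylamino in place of fluoro on an aromatic carbon. Among the compounds with values here, no measured pair shows this change, so the expectation is loose: a small step towards stronger inhibition of growth, perhaps none beyond the scatter. The estimated change is a 1.3-fold lower number from compound 1 to compound 3 (0.12 log units; within the scatter). Compound 3 is expected at 6000 nM, within a range of 1500 nM to 25000 nM.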

Compound 3, concentration for 50% growth inhibition: 12100 nM
Beside the measured number, compound 3's estimate is 2.0-fold (0.30 log units) below it; low and high end bracket the measured number.
By their numbers in this assay, from the lowest: compounds 1 and 3 (each within the scatter of the next); then compound 2.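

On an aromatic carbon, para to a large group, dimethylamino in place of fluoro gives a 1.5-fold higher number from compound 1 to compound 3 (0.18 log units; within the scatter) in this assay, so at this place a group of 3 heavy atoms reads the same as one of a single heavy atom. This one pair therefore shows no clear effect of the swap on growth inhibition. Nothing measured here offers an explanation for this result. From the compounds shown here alone, whether a carboxylic acid, a primary amine or a methoxy group at this place would move the number beyond the scatter stays open.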